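A few compounds are considered here, and "the series" means these few. Any claim that something is new, unique, unknown or untested is made for them only; others in the source may bear on it.

Measured in a functional assay on DU-145 cells (Homo sapiens) for inhibition; on this read-out lower numbers stand for stronger inhibition and higher numbers for weaker inhibition:
- Compound 1 `Oc1cccc(-c2cc(-c3ccccc3F)cc(-c3ccccc3O)n2)c1`: 35600 nM
- Compound 2 `Oc1ccc(-c2cc(-c3ccccc3F)cc(-c3ccccc3O)n2)cc1`: > 50000 nM, a limit of the assay and not a number

Compound 2 has no exact position on this read-out, and its standing is only (the limit of > 50000 nM in this assay, at which 1 of the 2 values shown sits).

Compound 3 `Oc1ccc(-c2cc(-c3ccccc3F)cc(-c3ccc(O)cc3)n2)cc1` has not yet been measured. Its difference from compound 2 is 4-hydroxyphenyl in place of 2-hydroxyphenyl on an aromatic carbon.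

Within the data shown here, only one measured step bears on this change: an at least 1.4-fold higher number from compound 1 to compound 2 (0.14 log units; that floor lies within the scatter). That step leaves the 2-hydroxyphenyl group in place, so it gives only indirect guidance, and it offers no measured size for removing that group. Among the measured compounds shown here, compound 1 reads 35600 nM, the only exact value, and weak inhibition is expected on that reading. No strong gain in this assay is therefore expected, and compound 3 may well return only a limit as well.

The expected step is a number no higher from compound 2 to compound 3 (the limit leaves the size open), with no change beyond the scatter anticipated.

The estimate for compound 3 is 50000 nM, with an expected range of 18000 nM to 120000 nM.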

Compound 3, half-maximal inhibitory concentration: 7780 nM
The estimate for compound 3 lay 6.4-fold (0.81 log units) above the measured number; measured number outside the range, below it.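

In this assay, 4-hydroxyphenyl in place of 2-hydroxyphenyl, on the aromatic carbon next to the ring nitrogen, gives an at least 6.4-fold lower number from compound 2 to compound 3 (0.80 log units; beyond the scatter). Among these compounds, the earlier step left this position untouched and changed only the other hydroxyphenyl group, so this is the first sign that the series responds to the group placed here, and that a 2-hydroxyphenyl group at this position is not required for inhibition, with compound 3 reading 7780 nM. Compound 2 stands at a limit of the assay and not a number, so the step gives only a floor for the change: the limit of > 50000 nM in this assay, at which 1 of the 3 values shown sits.

The compounds shown leave open whether the hydroxyl itself matters at this position, since a plain phenyl, a 4-methoxyphenyl or a 4-aminophenyl group would separate the ring from its substituent, and whether a 3-hydroxyphenyl group here would read like the 4-hydroxyphenyl group. They also leave open how far the 2-fluorophenyl group contributes, as it stays constant throughout, and whether a chlorine or a methyl group in place of its fluorine would shift the reading.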